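Para-methyl replaces meta-nitro on the pendant phenyl ring

The source may report more compounds than this note shows. Statements on the series, on what has been measured and on what is new or still open speak of the compounds shown alone.

Compound 3 `COc1cc(-n2cnc3ccc(-c4cccc([N+](=O)[O-])c4)cc32)cc(OC)c1OC` gives 5410 nM in a functional assay on A549 cells (Homo sapiens) for antiproliferative activity, read by MTT assay, with a stated time of 72 h (a lower number here means a stronger inhibitor, a higher number a weaker inhibitor), the highest of the two plain numbers; compound 2 `COc1cccc(-c2ccc3ncn(-c4cc(OC)c(OC)c(OC)c4)c3c2)c1` gives 3180 nM, and the two lie within the scatter. Compound 1 `COc1cc(-n2cnc3ccc(-c4ccc(Cl)cc4)cc32)cc(OC)c1OC` reaches only a limit, > 10000 nM, so its number is not known. The step to compound 4 `COc1cc(-n2cnc3ccc(-c4ccc(C)cc4)cc32)cc(OC)c1OC` is 4-methylphenyl in place of 3-nitrophenyl on an aromatic carbon. The steps that touch compound 3 are an at least 1.8-fold lower number from compound 1 to compound 3 (0.26 log units; that floor lies within the scatter) and a 1.7-fold higher number from compound 2 to compound 3 (0.23 log units; within the scatter). Compound 4 carries a para substituent, as compound 1 does, and compound 1 sits at a limit (the limit of > 10000 nM in this assay, at which 1 of the 3 values shown sits); compound 3 carries the meta-nitro that gave an at least 1.8-fold lower number from compound 1 to compound 3 (0.26 log units; that floor lies within the scatter). He therefore expects a higher number, a 1.5-fold higher number from compound 3 to compound 4 (0.17 log units; within the scatter). For compound 4 he estimates 8000 nM, between 3000 nM and 20000 nM, with a fair chance that only a limit is reported.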

Compound 4, half-maximal inhibitory concentration: 1940 nM
Estimate against measurement, compound 4: 4.1-fold (0.62 log units) above; the measured number lies below the stated range.
By their numbers in this assay, from the lowest: compounds 4, 2 and 3 (each within the scatter of the next, the first and the last beyond it). At a limit, above all of these: compound 1.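

In this assay, among these compounds, 4-methylphenyl on this aromatic carbon gives a 2.8-fold lower number from compound 3 to compound 4 (0.45 log units; beyond the scatter), the only step here between two plain numbers that lies beyond the scatter. Against 3-methoxyphenyl it gives a 1.6-fold lower number from compound 2 to compound 4 (0.21 log units; within the scatter), so compound 2 and compound 4 cannot be told apart. A substituent at the 4-position of this ring therefore need not end activity, as methyl in place of chloro gives an at least 5.1-fold lower number from compound 1 to compound 4 (0.71 log units; beyond the scatter), though compound 1 stands at a limit and this step is only a floor: the limit of > 10000 nM in this assay, at which 1 of the 4 values shown sits.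

As far as these compounds go, whether an amine on the pendant phenyl ring, or a longer chain in place of the methyl, would keep this level remains open.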